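Three aryl variants at a limit and a fourth to come

This account rests on a few compounds, and the source may have more. Where it says the series, first, only, none or still open, it means among the compounds named here.

Compound 1 `OC[C@H]1O[C@@H](n2cnc3c(NCc4ccccc4Br)ncnc32)[C@H](O)[C@@H]1O` carries a 2-bromophenyl group on a saturated chain carbon bound to a nitrogen on an aromatic ring. In a functional assay on HOS cells (Homo sapiens) for antiproliferative activity, with a stated time of 72 h (on this read-out higher numbers stand for weaker inhibition and lower numbers for stronger inhibition), compound 1 gives > 166000 nM, which is a limit of the assay and not a number. Compound 2 `OC[C@H]1O[C@@H](n2cnc3c(NCc4ccc(Br)cc4)ncnc32)[C@H](O)[C@@H]1O` carries a 4-bromophenyl group at the same place. In this assay compound 2 gives > 166000 nM, again a limit rather than a number. Compound 3 `COc1ccc(CNc2ncnc3c2ncn3[C@@H]2O[C@H](CO)[C@@H](O)[C@H]2O)c(OC)c1` carries a 2,4-dimethoxyphenyl group there. In this assay compound 3 gives > 166000 nM, also a limit. Compound 3 thus stands where all three measured values sit, at the limit of > 166000 nM in this assay, at which 3 of the 3 values shown sit. The steps a step that the two limits leave unreadable from compound 1 to compound 2, a step that the two limits leave unreadable from compound 1 to compound 3 and a step that the two limits leave unreadable from compound 2 to compound 3 accordingly have no readable size. Compound 4 `COc1cccc(CNc2ncnc3c2ncn3[C@@H]2O[C@H](CO)[C@@H](O)[C@H]2O)c1O` differs from compound 3 by 2-hydroxy-3-methoxyphenyl in place of 2,4-dimethoxyphenyl on a saturated chain carbon bound to a nitrogen on an aromatic ring. The measured steps that bear on this change, those ending at compound 3, were unreadable, so no step beyond the scatter can be foreseen in this assay in either direction, and a further limit is the likeliest outcome. Compound 4 is therefore estimated at 200000 nM, between 80000 nM and 600000 nM. This estimate means an expected step that the limit leaves unreadable from compound 3 to compound 4.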

Compound 4, half-maximal inhibitory concentration: > 166000 nM
Compound 4: no number, only a limit; the forecaster's own chance of this, stated with the estimate: 85%; the middle value does not contradict the limit.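

Compound 4 also gives only a limit of the assay, so in this assay none of the steps joining it to compound 1, compound 2 and compound 3 can be read: the limit of > 166000 nM in this assay, at which 4 of the 4 values shown sit.

The compounds shown leave open whether any of these four aryl groups differs from the others in antiproliferative activity, and by how much.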